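Cytotoxicity notes on a protected nucleoside sultone series

The source may hold more compounds than are shown below. What is called first, only, known or untested is meant among the compounds shown, and "the series" means these compounds.

compound 1 `CCOC(=O)CNC(=O)NC1=CS(=O)(=O)O[C@@]12[C@@H](CO[Si](C)(C)C(C)(C)C)O[C@@H](n1cc(C)c(=O)n(C)c1=O)[C@@H]2O[Si](C)(C)C(C)(C)C`: 16000 nM
compound 2 `Cc1cn([C@@H]2O[C@H](CO[Si](C)(C)C(C)(C)C)[C@@]3(OS(=O)(=O)C=C3NCC(=O)OCc3ccccc3)[C@H]2O[Si](C)(C)C(C)(C)C)c(=O)n(C)c1=O`: >= 400000 nM

In a functional assay on HEL cells (Homo sapiens) for cytotoxicity, read by microscopy (on this read-out lower numbers stand for higher toxicity in this test and higher numbers for lower toxicity in this test), compound 1 gives 16000 nM. For compound 2 only a limit of the assay is recorded, >= 400000 nM (the limit of >= 400000 nM in this assay, at which 1 of the 2 values shown sits). Compound 3 `Cc1cn([C@@H]2O[C@H](CO[Si](C)(C)C(C)(C)C)[C@@]3(OS(=O)(=O)C=C3NC(=O)NC(=O)c3ccccc3)[C@H]2O[Si](C)(C)C(C)(C)C)c(=O)n(C)c1=O` carries benzoylcarbamoyl in place of (benzyloxycarbonyl)methyl on an amine nitrogen. Among the measured compounds shown here, the single measured step, an at least 25-fold higher number from compound 1 to compound 2 (1.39 log units; beyond the scatter), went from ((ethoxycarbonyl)methyl)carbamoyl to (benzyloxycarbonyl)methyl. Reversing toward a benzoylcarbamoyl group on compound 3 is therefore expected to give a lower number, an at least 6.6-fold lower number from compound 2 to compound 3 (0.82 log units; beyond the scatter), though with compound 2 at a limit the size is uncertain. Compound 3 is estimated at 60000 nM, range 12000 nM to 400000 nM.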

Compound 3, minimum cytotoxic concentration: >= 80000 nM
Compound 3 ended at the assay's limit; the forecaster's own chance of this, stated with the estimate: 35%; middle value at least 1.3-fold (0.12 log units) from the limit.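

In this assay compound 3 also sits at a limit of the assay, >= 80000 nM. The step from compound 2 to compound 3 cannot be read, as both values are limits. Benzoyl in place of (ethoxycarbonyl)methyl on an amide-type nitrogen gives an at least 5.0-fold higher number from compound 1 to compound 3 (0.69 log units; beyond the scatter), so a carbamoyl link on this amine nitrogen does not by itself go with the lower number seen for compound 1.

As far as these compounds go, the order of compound 2 and compound 3 stays open. So does whether a carboxylic acid or a longer alkyl chain at the end of the carbamoyl group would stay near compound 1 or move away from it.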